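Swapping methoxy for dimethylamino on a piperidine amide

The source may report more compounds than this note shows. Statements on the series, on what has been measured and on what is new or still open speak of the compounds shown alone.

Measured compounds:
- compound 1, `COc1ccc(/C=C/C=C/C=C/C(=O)N2CCCCC2)cc1`: 1.08%
- compound 2, `COc1cc(/C=C/C=C/C(=O)N2CCCCC2)cc(OC)c1OC`: 66.7%
- compound 3, `O=C(/C=C/C=C/c1ccc(O)cc1)N1CCCCC1`: 44.4%

These three compounds share a piperidine amide joined to an aromatic ring through a chain of conjugated double bonds, and they were tested in an assay for inhibition of Polyunsaturated fatty acid 5-lipoxygenase (Homo sapiens), read by spectrophotometry, tested at 20 uM; a lower number here means less inhibition, a higher number more inhibition at the concentration tested (going by the name of the read-out). Compound 1 sits at the bottom of the three numbers, with 1.08%. The nearest number belongs to compound 3, whose value of 44.4% lies beyond the scatter above it, and compound 2, with 66.7%, stands further away still. Among the measured compounds shown here, no single-change step between measured compounds is available, so the effect of any one change is unknown here.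

Compound 4, `CN(C)c1ccc(/C=C/C=C/C=C/C(=O)N2CCCCC2)cc1`, is not yet measured. It differs from compound 1 in one place: dimethylamino in place of methoxy on an aromatic carbon. The change is small in the count of atoms and keeps one hydrogen-bond acceptor. With nothing measured to guide the direction, the step from compound 1 is expected to be modest, most likely no larger than the scatter, and expressed as a number 10.9 percentage points higher from compound 1 to compound 4 (beyond the scatter). For compound 4 the expected value in this assay is 12%, estimated to fall between 0% and 40%.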

Compound 4, a percentage reported as inhibition, at one concentration (the size of the read-out at that concentration, not a potency): 27.4%
Compound 4: the middle estimate sits 15.4 percentage points below what was measured; measured number inside the range.
By their numbers in this assay, from the lowest: compound 1; then compound 4; then compound 3; then compound 2.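

In this assay, among the compounds shown here, this is the first change that can be read on its own: with dimethylamino in place of methoxy on an aromatic carbon, para to a large group, the result is a number 26.3 percentage points higher from compound 1 to compound 4 (beyond the scatter). The shared core stays the same, and the two groups match in their counts of hydrogen-bond donors and acceptors and in carrying no net charge, so those counts alone do not fix the number at this position. Why the swap raises inhibition cannot be said from what is available here.

On these data alone, whether a diethylamino group or a plain amine on the same aromatic carbon would go further remains open. Compound 2 and compound 3 each differ from compound 1 in more than one place, so the chain and the other ring groups cannot yet be judged separately.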